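This account rests on a few compounds, and the source may have more. Where it says the series, first, only, none or still open, it means among the compounds named here.

Compound 1 `COc1ccc(Cn2c(O)nc3c(N)ncnc32)cc1`: 10 uM
Compound 2 `CCCCOc1nc(N)c2[nH]c(=O)n(Cc3ccccc3)c2n1`: 0.001 uM
Compound 3 `CCCCCSc1nc(N)c2nc(O)n(Cc3ccccc3)c2n1`: 10 uM

All three values come from a functional assay (spleen, spleen) for activation, with Mus musculus as the target; a lower number here means that less compound is needed, a higher number that more compound is needed for the effect. Compound 3 stands level with compound 1 at the digits shown, and these two together give the highest numbers of the set, while compound 2 lies far lower. Compound 4 `COc1nc(N)c2nc(O)n(Cc3ccccc3)c2n1` has not yet been measured. It differs from compound 3 in a single place: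

methoxy in place of pentylsulfanyl on an aromatic carbon

Compound 2, whose core carries an ether chain rather than a thioether, gives 0.001 uM, so a move toward a lower number is expected from compound 3 to compound 4, though compound 4 carries a shorter chain than compound 2. The expected step is a 100-fold lower number from compound 3 to compound 4 (2.00 log units; beyond the scatter). Compound 4 is estimated to give 0.1 uM, within a range from 0.005 uM to 3 uM.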

Compound 4, minimum effective concentration: 0.1 uM
Compound 4: the middle estimate sits on the measured number at the digits printed; low and high end bracket the measured number.
By their numbers in this assay, from the lowest: compound 2; then compound 4; then compounds 1 and 3 (each within the scatter of the next).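

In this assay the exchange of pentylsulfanyl for methoxy on the aromatic carbon between two ring nitrogen atoms gives a 100-fold lower number from compound 3 to compound 4 (2.00 log units; beyond the scatter) and so shows that the number depends heavily on the group at this position. This one step changes both the linking atom, sulfur to oxygen, and the chain length, so it cannot show which of the two matters. Nothing measured here explains the size of the step.

Still open, going by these compounds, is how methylsulfanyl or a pentyloxy chain would compare at this position, since each would change only one of those two features.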